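A Difluorophenyl Hydrazone in a Series Near the Limit

This account rests on a few compounds, and the source may have more. Where it says the series, first, only, none or still open, it means among the compounds named here.

Three hydrazones on one shared core have been examined in a functional assay on HCT-116 cells (Homo sapiens) for antiproliferative activity, read by MTT assay; a higher number here means a weaker inhibitor, a lower number a stronger inhibitor. Compound 1, `Cn1c(=O)c(=O)n(C2CCCC2)c2nc(N/N=C/c3ccccc3)ncc21`, gives there only a limit of the assay, > 100000 nM. Compound 2, `Cc1cccc(/C=N/Nc2ncc3c(n2)n(C2CCCC2)c(=O)c(=O)n3C)c1`, likewise gives only a limit of the assay, > 100000 nM. Compound 3, `Cn1c(=O)c(=O)n(C2CCCC2)c2nc(N/N=C/c3ccco3)ncc21`, gives a number, 78700 nM. The step that the two limits leave unreadable from compound 1 to compound 2 runs between two limits and cannot be read; the step of an at least 1.2-fold lower number from compound 2 to compound 3 (0.10 log units; that floor lies within the scatter) ends within the scatter, and an at least 1.2-fold lower number from compound 1 to compound 3 (0.10 log units; that floor lies within the scatter) is of the same small kind. The common reading here is the limit of > 100000 nM in this assay, at which 2 of the 3 values shown sit.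

The unmeasured compound 4, `Cn1c(=O)c(=O)n(C2CCCC2)c2nc(N/N=C/c3ccc(F)cc3F)ncc21`, differs from compound 2 by 2,4-difluorophenyl in place of 3-methylphenyl on a carbon with a double bond to nitrogen. Among the compounds with values here, no measured step exchanges one phenyl pattern for a fluorinated one, so the only guidance comes from the limits at which compound 1 and compound 2 sit and from the small step to compound 3. Compound 4 is therefore expected to stay at or near the limit, with an estimate of 100000 nM and a range from 40000 nM to 250000 nM. This expectation corresponds to a step of a number no higher from compound 2 to compound 4 (the limit leaves the size open), none beyond the scatter.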

Compound 4, half-maximal inhibitory concentration: 19800 nM
Compound 4: middle estimate off by 5.1-fold (0.70 log units), on the high side, and the stated range ends above it.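

In this assay, the earlier compounds had shown no change at the carbon with a double bond to nitrogen that could be read beyond the scatter, whereas 2,4-difluorophenyl gives an at least 5.0-fold lower number from compound 2 to compound 4 (0.70 log units; beyond the scatter) and an at least 5.0-fold lower number from compound 1 to compound 4 (0.70 log units; beyond the scatter), both measured from a limit of the assay. Set against furan-2-yl, the one earlier group with a number, it gives a 4.0-fold lower number from compound 3 to compound 4 (0.60 log units; beyond the scatter), the only one of these steps with a fixed size. Even so, the limit still marks much of this small series: the limit of > 100000 nM in this assay, at which 2 of the 4 values shown sit.

The compounds shown leave open whether a single fluorine on the phenyl ring would give a similar step, or whether both fluorine atoms are needed. They also leave open how a chlorophenyl group, or a phenyl ring carrying an amine or a carboxylic acid, would read at this position.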